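Cyclohexyl for 4-methylbenzyl on the imidazole core

The source may hold more compounds than are shown below. What is called first, only, known or untested is meant among the compounds shown, and "the series" means these compounds.

Measured compounds in an in vitro functional assay on cells for agonist activity at Bombesin receptor subtype-3 (Mus musculus), read by luminescence and calcium flux; on this read-out lower numbers stand for an effect already at smaller amounts and higher numbers for an effect only at larger amounts of compound:
compound 1 `CC(C)(C)CCc1cnc(CCc2ccc(-c3ccccc3C(=O)O)cc2)[nH]1` gives 6.2 nM
compound 2 `N#Cc1ccc(Cc2cnc(CCc3ccc(-c4ccccc4C(=O)O)cc3)[nH]2)cc1` gives 723 nM
compound 3 `Cc1ccc(Cc2cnc(CCc3ccc(-c4ccccc4C(=O)O)cc3)[nH]2)cc1` gives 162 nM

Compound 3 stands second highest of the three numbers. Its nearest neighbour is compound 2, a 4.5-fold lower number from compound 2 to compound 3 (0.65 log units; beyond the scatter); its furthest is compound 1, a 26-fold higher number from compound 1 to compound 3 (1.42 log units; beyond the scatter).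

Compound 4 `O=C(O)c1ccccc1-c1ccc(CCc2ncc(C3CCCCC3)[nH]2)cc1` has not yet been measured. It differs from compound 3 in one place: cyclohexyl in place of 4-methylbenzyl on an aromatic carbon.

Among the measured compounds shown here, two measured steps bear on this change. Both a 120-fold higher number from compound 1 to compound 2 (2.07 log units; beyond the scatter) and a 26-fold higher number from compound 1 to compound 3 (1.42 log units; beyond the scatter) replace an aliphatic neopentyl chain with an aromatic benzyl group and give large increases in the number, so the aliphatic group appears to carry most of the effect. For the measured compounds named here, the step to compound 4 runs the other way, putting an aliphatic cyclohexyl in place of the aromatic 4-methylbenzyl, though the cyclohexyl is smaller and sits directly on the ring carbon rather than on a saturated chain carbon, and no measured compound has exactly this arrangement.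

Compound 4 is therefore expected to give a modest to large lower number, a 4.1-fold lower number from compound 3 to compound 4 (0.61 log units; beyond the scatter), with an estimate of 40 nM in this assay, in the range 8 nM to 200 nM.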

Compound 4, half-maximal effective concentration: 14.7 nM
The estimate for compound 4 lay 2.7-fold (0.43 log units) above the measured number, and the stated range covers the measured number.
By their numbers in this assay, from the lowest: compound 1; then compound 4; then compound 3; then compound 2.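

In this assay the cyclohexyl group at this aromatic carbon of the five-membered ring gives an 11-fold lower number from compound 3 to compound 4 (1.04 log units; beyond the scatter) and a 49-fold lower number from compound 2 to compound 4 (1.69 log units; beyond the scatter) as it replaces the two benzyl groups, so a low number here does not depend on an open chain such as 3,3-dimethylbutyl, and a saturated ring also reaches it. The open chain still keeps a small edge, with a 2.4-fold higher number from compound 1 to compound 4 (0.37 log units; beyond the scatter) on going to cyclohexyl, a modest step that is printed as beyond the scatter and stands well short of the large steps from the two benzyl compounds. Among these four compounds, then, both groups without an aromatic ring give lower numbers than both benzyl groups, and no compound goes against that order, but the data shown offer no explanation for it.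

On these data alone, what stays open is whether the ring's saturation or its attachment matters more, since cyclohexyl differs from 4-methylbenzyl in both, and phenyl or cyclohexylmethyl at the same carbon would separate the two. As far as these compounds go, it is also open how far the cyclohexyl ring accepts added groups, such as a hydroxyl or an amine, or a change of ring size to cyclopentyl.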